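Extending the methoxyoxy chain of compound 3

The source may report more compounds than this note shows. Statements on the series, on what has been measured and on what is new or still open speak of the compounds shown alone.

Measured in a functional assay on FM3A cells (Mus musculus) for cytotoxicity; a lower number here means that less compound is needed, a higher number that more compound is needed for the effect:
- compound 1 `COOC1(OOC)CCCCCCCCCCC1`: 1500 nM
- compound 2 `COOC1(OOCCC(=O)OC)CCCCCCCCCCC1`: 1400 nM
- compound 3 `COOC1(OC)CCCCCCCCCCC1`: 19000 nM

Compound 3 has the highest number of the three in this assay. The gaps to the other two are large: a 13-fold higher number from compound 1 to compound 3 (1.10 log units; beyond the scatter) and a 14-fold higher number from compound 2 to compound 3 (1.13 log units; beyond the scatter). Both lie beyond the scatter, while compound 1 and compound 2 sit within the scatter of each other.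

The next structure is compound 4 `CCCOOC1(OC)CCCCCCCCCCC1`, which turns methoxyoxy into propoxyoxy, with ethyl in place of hydrogen on a saturated chain carbon bound to an oxygen on an unsaturated carbon.

The two large steps replace a different group, so they say little about this change. The closest measured precedent is a 1.1-fold lower number from compound 1 to compound 2 (0.03 log units; within the scatter), where (methoxycarbonyl)methyl takes the place of hydrogen on a saturated chain carbon bound to an oxygen. That is a single example with a different added group and a different partner group on the shared core, so it supports only a cautious expectation. No step beyond the scatter is expected in this assay, and no direction can be assigned.

The estimate corresponds to a 1.2-fold lower number from compound 3 to compound 4 (0.07 log units; within the scatter), an expected step within the scatter. For compound 4 the expected value is 16000 nM, with an estimated range of 6000 nM to 40000 nM.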

Compound 4, half-maximal effective concentration: > 37000 nM
Compound 4: no number, only a limit; the forecaster's own chance of this, stated with the estimate: 5%; middle value at least 2.3-fold (0.36 log units) away from the limit.
By their numbers in this assay, from the lowest: compounds 2 and 1 (each within the scatter of the next); then compound 3. At a limit, above all of these: compound 4.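

In this assay compound 4 carries a limit and not a number: > 37000 nM. Ethyl in place of hydrogen on a saturated chain carbon bound to an oxygen, which turns methoxyoxy into propoxyoxy, gives an at least 1.9-fold higher number from compound 3 to compound 4 (0.28 log units; that floor lies within the scatter); this excludes a lower number for this change on compound 3, something the earlier compounds could not show, but the floor of the step is still too small to establish a change beyond the scatter. The size of the step therefore stays unread, and the reading rests on a single compound at the limit: the limit of > 37000 nM in this assay, at which 1 of the 4 values shown sits.

The compounds shown leave open how a longer chain such as butoxyoxy, or a chain ending in a carboxylic acid or an amine, would behave at this position on compound 3. Among these compounds, they also leave open whether ethyl in place of hydrogen would give a similar result on a partner group like the one in compound 1, where the only related step, a 1.1-fold lower number from compound 1 to compound 2 (0.03 log units; within the scatter), adds a different group.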